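This account rests on a few compounds, and the source may have more. Where it says the series, first, only, none or still open, it means among the compounds named here.

In a functional assay on the whole organism (strain Wistar albino) for inhibition, with Rattus norvegicus as the target, read by paw edema, with stated times of 30 min and 2.5 h, at a dose of 20 mg/kg by the oral route (a lower number here means less inhibition, a higher number more inhibition at the dose given (going by the name of the read-out)), compound 2 `CC(C)Cc1ccc(C(C)c2nnc3sc(-c4ccccc4Cl)nn23)cc1` gives 58%. Compound 1 `Cc1nn2c(C(C)c3ccc(CC(C)C)cc3)nnc2s1` gives 56% in this assay, and the two numbers lie within the scatter of each other: the step of a number 2 percentage points higher from compound 1 to compound 2 (within the scatter) is within the scatter, so the two compounds cannot be told apart on these data. Compound 3 `CC(C)Cc1ccc(C(C)c2nnc3sc(-c4ccc([N+](=O)[O-])cc4Cl)nn23)cc1` has not yet been measured in this assay. It differs from compound 2 in one place: nitro in place of hydrogen on an aromatic carbon so that the 2-chlorophenyl of compound 2 becomes a 2-chloro-4-nitrophenyl. Among the measured compounds shown here, no measured step touches a nitro group; the only step known, a number 2 percentage points higher from compound 1 to compound 2 (within the scatter), changed the same ring position from methyl to 2-chlorophenyl and stayed within the scatter. There is thus no ground for expecting a shift beyond the scatter. Compound 3 is expected to give about 58% in this assay, with a range from 46% to 70%. The step of no change at the digits printed from compound 2 to compound 3 (within the scatter) is expected to stay within the scatter.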

Compound 3, a percentage reported as inhibition, in the whole organism at one dose (the size of the read-out at that dose, not a potency): 67%
Estimate against measurement, compound 3: 9 percentage points below; measured number inside the range.
By their numbers in this assay, from the lowest: compounds 1, 2 and 3 (each within the scatter of the next, the first and the last beyond it).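

In this assay, nitro in place of hydrogen on the 2-chlorophenyl, para to a large group and meta to the chloro group, gives a number 9 percentage points higher from compound 2 to compound 3 (within the scatter) and so leaves compound 2 and compound 3 not told apart on these data. Among the compounds shown here, the whole change from methyl to 2-chloro-4-nitrophenyl gives a number 11 percentage points higher from compound 1 to compound 3 (beyond the scatter) and is the first step at this position to pass the scatter, though only modestly, while each of its two parts taken alone stays within it. Nothing available accounts for this result.

From the compounds shown here alone, whether the nitro group would read the same on a phenyl ring without the chloro group stays open. Also open, going by these compounds, is how an amine or a carboxylic acid would read in the place of the nitro group on this ring.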